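Aryl amide substituent swap in the reporter series

The compounds below may be only part of what the source reports. "The series", "measured", "known", "first", "only" and "open" are said of these compounds alone.

Compound 1 `CC(C)OC(=O)C1=CN(C(=O)c2ccc(F)cc2)CC(C)(C)c2cc(C#N)[nH]c21` gives 5 nM in an assay on HEK293 cells for agonist activity at Bile acid receptor (Homo sapiens), read by a luciferase reporter (a higher number here means that more compound is needed for the effect, a lower number that less compound is needed), the lowest of the three numbers. Going by the values given here, compound 2 `CC(C)OC(=O)C1CN(C(=O)c2cccc(Cl)c2)CC(C)(C)c2cc(C#N)[nH]c21` gives 1300 nM and compound 3 `CC(C)OC(=O)C1CN(C(=O)C2CCOCC2)CC(C)(C)c2cc(C#N)[nH]c21` gives 3300 nM; both differ from compound 1 at the core as well as at the amide, and no single step links either to it. Among the compounds with values here, the one measured step, a 2.5-fold higher number from compound 2 to compound 3 (0.40 log units; beyond the scatter), concerns the group on the carbonyl carbon but touches neither fluoro nor cyano. Compound 4 `CC(C)OC(=O)C1=CN(C(=O)c2ccc(C#N)cc2)CC(C)(C)c2cc(C#N)[nH]c21` differs from compound 1 by cyano in place of fluoro on an aromatic carbon. Nothing measured bears directly on this change, so the expectation for the step in this assay is a 1.6-fold higher number from compound 1 to compound 4 (0.20 log units; within the scatter), nothing beyond the scatter in either direction. Compound 4 is therefore estimated at 8 nM, with a range from 2 nM to 35 nM.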

Compound 4, half-maximal effective concentration: 35 nM
Compound 4: middle estimate off by 4.4-fold (0.64 log units), on the low side; the measured number falls inside the stated range.
By their numbers in this assay, from the lowest: compound 1; then compound 4; then compound 2; then compound 3.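

At this aromatic carbon, para to a large group, the 4-fluorophenyl to 4-cyanophenyl change on the core of compound 1 is not silent in this assay: it gives a 7.0-fold higher number from compound 1 to compound 4 (0.85 log units; beyond the scatter). Going by these compounds alone, this is the first measured step at this position, where the earlier compounds offered only a change of the whole group on the carbonyl carbon. Nothing available explains the size of this step. Open, going by these compounds, are how a methoxy group or an amine would read at this carbon, and whether cyano in place of fluoro gives a similar step on the core of compound 2.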